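Replacing an Ester-Bearing Ring with a Carboxylic Acid

The source may hold more compounds than are shown below. What is called first, only, known or untested is meant among the compounds shown, and "the series" means these compounds.

Compound 1 `CCCCCCCCc1ccc(OCC(=O)Cn2nnc(-c3cccc(C(=O)OC)c3)n2)cc1` was tested in an assay on microsomes from brain for inhibition of Fatty-acid amide hydrolase 1 (Rattus norvegicus), read by fluorescence and HPLC, with a stated time of 60 min (on this read-out higher numbers stand for weaker inhibition and lower numbers for stronger inhibition), where compound 1 gives 34 nM. Among the three compounds measured, compound 1 stands second highest; compound 2 `CCCCCCCCc1ccc(OCC(=O)Cn2nnc(-c3ccccn3)n2)cc1` gives 18 nM, and compound 3 `CCCCCCCCc1ccc(OCC(=O)Cn2nnc(C(=O)OC)n2)cc1` gives 88 nM. The step of a 1.9-fold lower number from compound 1 to compound 2 (0.28 log units; within the scatter) is small, while a 2.6-fold higher number from compound 1 to compound 3 (0.41 log units; beyond the scatter) and a 4.9-fold higher number from compound 2 to compound 3 (0.69 log units; beyond the scatter) are modest. Compound 4 `CCCCCCCCc1ccc(OCC(=O)Cn2nnc(-c3ccc(C(=O)O)cc3)n2)cc1` differs from compound 1 in one place: 4-carboxyphenyl in place of 3-(methoxycarbonyl)phenyl on an aromatic carbon. Among the measured compounds shown here, no measured step removes an ester or changes the position on this ring, so the measured steps give only a loose guide: aryl groups at this position gave similar numbers in compound 1 and compound 2. A small step, a 1.3-fold higher number from compound 1 to compound 4 (0.12 log units; within the scatter), is therefore expected for compound 4. Compound 4 is estimated at 45 nM, with a range from 15 nM to 140 nM.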

Compound 4, half-maximal inhibitory concentration: 90 nM
The estimate for compound 4 lay 2.0-fold (0.30 log units) below the measured number, and the stated range covers the measured number.
By their numbers in this assay, from the lowest: compounds 2 and 1 (each within the scatter of the next); then compounds 3 and 4 (each within the scatter of the next).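

The group at this place on the five-membered ring clearly matters, since 4-carboxyphenyl gives a 2.6-fold higher number from compound 1 to compound 4 (0.42 log units; beyond the scatter) and a 5.0-fold higher number from compound 2 to compound 4 (0.70 log units; beyond the scatter). Aryl groups here are therefore not interchangeable, and the ring-bearing compound 4 matches the ring-free compound 3 with a 1.0-fold higher number from compound 3 to compound 4 (0.01 log units; within the scatter). No measurement shown here explains these steps.

On these data alone, this change alters both the ester and the group's place on the ring, so the contribution of each stays open. 3-Carboxyphenyl would separate the two, and an amine on this ring remains an open question.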